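Ring size on the nitrogen substituent: microsomal stability notes

This account rests on a few compounds, and the source may have more. Where it says the series, first, only, none or still open, it means among the compounds named here.

Measured so far:
compound 1 `CC(C)CCn1nc(C2=CCCC2)c(O)c(C2=NS(=O)(=O)c3cc(NS(C)(=O)=O)ccc3N2)c1=O` — 0.933 h
compound 2 `CS(=O)(=O)Nc1ccc2c(c1)S(=O)(=O)N=C(c1c(O)c(-c3cccs3)nn(CC3CCC3)c1=O)N2` — > 1 h

In an in vitro ADME assay on microsomes from liver (Homo sapiens) for metabolic stability, tested at 5 uM (on this read-out higher numbers stand for a longer-lived compound and lower numbers for a shorter-lived compound), compound 1 gives 0.933 h. In this assay compound 2 is reported only as a limit, > 1 h; no number is known for it, and it stands at the limit of > 1 h in this assay, at which 1 of the 2 values shown sits. For the measured compounds named here, no step between measured compounds that differ in one place is available, so the two values can only be read side by side.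

Compound 3 `CS(=O)(=O)Nc1ccc2c(c1)S(=O)(=O)N=C(c1c(O)c(-c3cccs3)nn(CCC3CCCC3)c1=O)N2` is not yet measured. It differs from compound 2 by cyclopentylmethyl in place of cyclobutyl on a saturated chain carbon bound to an aromatic nitrogen. Going by the values given here, with no measured step to lean on, the expectation is for no change beyond the usual scatter, or a modest shortening, as an at least 1.1-fold lower number from compound 2 to compound 3 (0.07 log units; that floor lies within the scatter). Compound 3 is accordingly estimated at 0.85 h, with a range from 0.4 h to 1.8 h, and a fair chance that this assay again reports only a limit.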

Compound 3, half-life: > 1 h
Compound 3 ended at the assay's limit; the forecaster's own chance of this, stated with the estimate: 40%; at least 1.1-fold (0.07 log units) between middle value and limit.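

In this assay no step can be read from compound 2 to compound 3, since each is reported only as a limit: the limit of > 1 h in this assay, at which 2 of the 3 values shown sit.

On these data alone, whether cyclopentylmethyl in place of cyclobutyl on this chain changes the half-life at all remains open, as do the actual numbers for compound 2 and compound 3.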